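Adding an amino group to the nitro analogue

The source may hold more compounds than are shown below. What is called first, only, known or untested is meant among the compounds shown, and "the series" means these compounds.

Of the compounds shown here, three sharing one core have been measured in an assay for binding affinity to adenosine receptor A1 (Bos taurus); on this read-out higher numbers stand for weaker inhibition and lower numbers for stronger inhibition. Compound 1 `CCc1ccc(-c2nc3c(=O)n(C)c(=O)n(C)c3[nH]2)cc1` gives 0.8 nM, compound 3 `CCOc1ccc(-c2nc3c(=O)n(C)c(=O)n(C)c3[nH]2)cc1` gives 2 nM, and compound 2 `Cn1c(=O)c2nc(-c3ccc([N+](=O)[O-])cc3)[nH]c2n(C)c1=O` gives 8 nM. Compound 2 thus stands highest of the three: its step to compound 3 is a 4.0-fold lower number from compound 2 to compound 3 (0.60 log units; beyond the scatter), and the step from compound 1 to compound 2 is a 10-fold higher number from compound 1 to compound 2 (1.00 log units; beyond the scatter), while a 2.5-fold higher number from compound 1 to compound 3 (0.40 log units; beyond the scatter) separates the other two.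

The new compound 4 `Cn1c(=O)c2nc(-c3ccc([N+](=O)[O-])cc3N)[nH]c2n(C)c1=O` differs from compound 2 by amino in place of hydrogen on an aromatic carbon, placed on an aromatic carbon of the six-membered ring of carbon only, ortho to a large group and meta to the nitro group. Going by the values given here, every measured step swaps the group that sits where the nitro group stands; none adds a second group to that ring, so no measured step bears directly on this change. Among the compounds with values here, the only firm anchor is compound 2 itself at 8 nM. Within the data shown here, with no comparable precedent, the step of no change at the digits printed from compound 2 to compound 4 (within the scatter) is expected to stay modest and could run in either direction. Compound 4 is therefore estimated at 8 nM in this assay, within a range from 2.5 nM to 25 nM.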

Compound 4, half-maximal inhibitory concentration: 2.5 nM
Compound 4: the middle estimate sits 3.2-fold (0.51 log units) above what was measured, and the stated range covers the measured number.
By their numbers in this assay, from the lowest: compound 1; then compounds 3 and 4 (each within the scatter of the next); then compound 2.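

In this assay, going by these compounds alone, the step of a 3.2-fold lower number from compound 2 to compound 4 (0.51 log units; beyond the scatter) is the first view of this position, as every earlier step swapped the group where the nitro group stands and left the rest of that ring as it was. It shows that this aromatic carbon, ortho to a large group and meta to the nitro group, can carry an amino group without any loss in this read-out: the number goes down, by a margin beyond the scatter, while the nitro group stays in place. Nothing available accounts for this fall, and the result gives only its direction and size.

The compounds shown leave open whether the fall belongs to the amino group itself, since a hydroxyl, a methoxy, a methyl, a fluorine or a dimethylamino group on the same carbon would be needed to tell that. They also leave open whether an amino group on this carbon would lower the number in the same way with the ethyl or ethoxy group of compounds 1 and 3 in place of the nitro group.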